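A few compounds are considered here, and "the series" means these few. Any claim that something is new, unique, unknown or untested is made for them only; others in the source may bear on it.

Going by the values given here, compound 1 `CCN(C1=NCCN1)c1c(Br)cccc1Br` stands at the top of the three numbers so far in a physicochemical assay for acid dissociation, giving 11.1, though both other compounds lie within the scatter of it: compound 2 `CC(C)CN(C1=NCCN1)c1c(Br)cccc1Br` gives 11 and compound 3 `CC(C)CCN(C1=NCCN1)c1c(Br)cccc1Br` gives 10.9. Compound 4 `Brc1cccc(Br)c1N(CC1CCC1)C1=NCCN1` differs from compound 1 by cyclobutyl in place of methyl on a saturated chain carbon bound to a nitrogen on an aromatic ring. Among the compounds with values here, the steps that bear on this change, a number 0.10 log units lower from compound 1 to compound 2 (within the scatter) and a number 0.10 log units lower from compound 2 to compound 3 (within the scatter), each altered the same saturated chain carbon bound to a nitrogen on an aromatic ring, and a number 0.20 log units lower from compound 1 to compound 3 (within the scatter) stayed within the scatter as well. The step is therefore expected to be a number 0.10 log units lower from compound 1 to compound 4 (within the scatter), nothing beyond the scatter. Compound 4 is accordingly estimated at 11, with a range from 10.7 to 11.3.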

Compound 4, acid dissociation constant: 10.9
Compound 4: the middle estimate sits 0.10 log units above what was measured; low and high end bracket the measured number.
By their numbers in this assay, from the lowest: compounds 3, 4, 2 and 1 (each within the scatter of the next).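

In this assay, a ring now stands at this position, and cyclobutyl, with four heavy atoms where methyl has one, still gives only steps within the scatter: a number 0.20 log units lower from compound 1 to compound 4 (within the scatter), a number 0.10 log units lower from compound 2 to compound 4 (within the scatter) and no change at the digits printed from compound 3 to compound 4 (within the scatter). On a saturated chain carbon bound to a nitrogen on an aromatic ring, methyl, isopropyl, isobutyl and cyclobutyl thus give no step beyond the scatter among these four compounds. Nothing measured here speaks to why this is so. The compounds shown leave open whether an amine or a carboxylic acid at this place would give a step beyond the scatter.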